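The source may report more compounds than this note shows. Statements on the series, on what has been measured and on what is new or still open speak of the compounds shown alone.

Measured so far in a functional assay on CWR22R cells (Homo sapiens) for antiproliferative activity, read by propidium iodide staining, with a stated time of 96 h; on this read-out lower numbers stand for stronger inhibition and higher numbers for weaker inhibition
- compound 1 `CC(O)(COc1cccc(S(F)(F)(F)(F)F)c1)C(=O)Nc1ccc(S(F)(F)(F)(F)F)cc1` gives 17600 nM
- compound 2 `CC(O)(COc1cccc(OC(F)(F)F)c1)C(=O)Nc1ccc(S(F)(F)(F)(F)F)cc1` gives 17300 nM

Compound 1 and compound 2 lie within the scatter of each other, and no other measured number is available for comparison. Compound 3 `CC(O)(COc1cccc(S(F)(F)(F)(F)F)c1)C(=O)Nc1ccc(C(F)(F)F)cc1` is the next case. Its difference from compound 1 is a group of 4 heavy atoms (1 carbon, 3 fluorine; no ring) in place of a group of 6 heavy atoms (5 fluorine, 1 sulfur; no ring), on an aromatic carbon and the trifluoromethyl sits on an aromatic carbon of a six-membered aromatic ring of carbon only, para to a large group. For the measured compounds named here, the sole measured step (a 1.0-fold lower number from compound 1 to compound 2 (0.01 log units; within the scatter)) replaces the same group of 6 heavy atoms on a different aromatic carbon, so it bears only indirectly. Going by the values given here, no measured step covers the carbon changing here. On that thin basis, no step beyond the scatter is expected in this assay for this change. The estimated step is (a 1.2-fold lower number from compound 1 to compound 3 (0.07 log units; within the scatter)) and it stays within the scatter. For compound 3 the estimated value is 15000 nM with an expected range from 6000 nM to 35000 nM on repeat measurement.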

Compound 3, half-maximal inhibitory concentration: 15800 nM
Compound 3: middle estimate off by 1.1-fold (0.02 log units), on the low side; low and high end bracket the measured number.
By their numbers in this assay, from the lowest: compounds 3, 2 and 1 (each within the scatter of the next).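

Working notes: in this assay, trifluoromethyl entering for the group of 5 fluorine and 1 sulfur, on an aromatic carbon para to a large group, gives a 1.1-fold lower number from compound 1 to compound 3 (0.05 log units; within the scatter) and so adds a first measured step at this position. The step at a different aromatic carbon (a 1.0-fold lower number from compound 1 to compound 2 (0.01 log units; within the scatter)) also lies within the scatter, so neither replacement of this group among the compounds shown moves the number beyond it. Nothing available on these compounds accounts for this result.

From the compounds shown here alone, whether an amine, a carboxylic acid or a nitrile at this position would give a step beyond the scatter remains open. Also open, going by these compounds, is what a plain hydrogen in this place would give, and whether the two replacements would behave alike on the core of compound 2.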